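From 2,4-dimethylphenyl to 3,5-dimethylphenyl in compound 4

A few compounds are considered here, and "the series" means these few. Any claim that something is new, unique, unknown or untested is made for them only; others in the source may bear on it.

Results in an ADME assay on Huh7.5.1 cells (Homo sapiens) for cytotoxicity, read by ATP content, with a stated time of 48 h (on this read-out lower numbers stand for higher toxicity in this test and higher numbers for lower toxicity in this test), for three compounds:
compound 1 `Cc1oc(-c2ccc(Cl)cc2)nc1CN1CCC(C(=O)NCCCN2C[C@H](C)C[C@H](C)C2)CC1` gives 11500 nM
compound 2 `Cc1cccc(-c2nc(CN3CCC(C(=O)NCCCN4C[C@H](C)C[C@H](C)C4)CC3)c(C)o2)c1` gives 16500 nM
compound 3 `Cc1ccc(-c2nc(CN3CCC(C(=O)NCCCN4C[C@H](C)C[C@H](C)C4)CC3)c(C)o2)c(C)c1` gives 4110 nM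

Compound 3 at 4110 nM stands lowest of the three, and its gaps to both others lie beyond the scatter. Compound 4 `Cc1cc(C)cc(-c2nc(CN3CCC(C(=O)NCCCN4C[C@H](C)C[C@H](C)C4)CC3)c(C)o2)c1` has not yet been measured. The change from compound 3 is 3,5-dimethylphenyl in place of 2,4-dimethylphenyl on an aromatic carbon and amounts to 3,5-dimethylphenyl in place of 2,4-dimethylphenyl on an aromatic carbon. The closest evidence is a 4.0-fold lower number from compound 2 to compound 3 (0.60 log units; beyond the scatter) and it is a modest step, as is a 2.8-fold lower number from compound 1 to compound 3 (0.45 log units; beyond the scatter) while a 1.4-fold higher number from compound 1 to compound 2 (0.16 log units; within the scatter) stays within the scatter. By name, the 3,5-dimethylphenyl group of compound 4 resembles the 3-methylphenyl group of compound 2 at 16500 nM more than it resembles the group of compound 3, so a modest return toward higher numbers is expected. Among the compounds with values here, the expected rise is a 2.7-fold higher number from compound 3 to compound 4 (0.43 log units; beyond the scatter) in this assay and it rests on only three measured compounds. For compound 4 the estimated value is 11000 nM with an expected range of 5000 nM to 24000 nM in this estimate.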

Compound 4, half-maximal cytotoxic concentration in the Huh7.5.1 assay: 4050 nM
Beside the measured number, compound 4's estimate is 2.7-fold (0.43 log units) above it, and the stated range ends above it.
By their numbers in the Huh7.5.1 assay, from the lowest: compounds 4 and 3 (each within the scatter of the next); then compounds 1 and 2 (each within the scatter of the next).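

In the Huh7.5.1 assay, the 3,5-dimethylphenyl and 2,4-dimethylphenyl groups on this aromatic carbon are not told apart: a 1.0-fold lower number from compound 3 to compound 4 (0.01 log units; within the scatter). The low number of compound 3 is therefore not tied to the 2,4-dimethylphenyl pattern alone, as methyl in place of hydrogen on the 3-methylphenyl group gives a 4.1-fold lower number from compound 2 to compound 4 (0.61 log units; beyond the scatter), and 3,5-dimethylphenyl in place of 4-chlorophenyl gives a 2.8-fold lower number from compound 1 to compound 4 (0.45 log units; beyond the scatter). The same change does separate the two compounds in a physicochemical assay for permeability, using PAMPA; a higher number here means that the compound crosses the layer faster, a lower number that the compound crosses the layer more slowly: the measured apparent permeability of compound 3, 353 10^-6 cm/s, and of compound 4, 864 10^-6 cm/s, a 2.4-fold higher number (0.39 log units; beyond the scatter)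

In the physicochemical assay, compound 3 gives 353 10^-6 cm/s and compound 4 gives 864 10^-6 cm/s.

The compounds shown leave open whether the second methyl group itself goes with the lower number in the Huh7.5.1 assay, and whether the difference in the physicochemical assay has any bearing on that number. They also leave open how a methoxy or trifluoromethyl group at this phenyl would read.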